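This account rests on a few compounds, and the source may have more. Where it says the series, first, only, none or still open, it means among the compounds named here.

In an ADME assay on microsomes from liver (Homo sapiens) for metabolic stability, read by LC-MS, with a stated time of 30 min, tested at 1 uM (on this read-out lower numbers stand for a less stable compound and higher numbers for a more stable compound), compound 2 (`O=C(NCc1ccc(S(=O)(=O)c2cccc(C(F)(F)F)c2)cc1)c1cc2ccncc2o1`) gives 48% and compound 3 (`O=C(NCc1ccc(S(=O)(=O)N2CCCCC2)cc1)c1cc2ccncc2o1`) gives 56%, two values within the scatter of each other. Compound 1 (`O=C(NCc1ccc(S(=O)(=O)c2ccccc2)cc1)c1ccc2nccn2c1`) gives 77%. Compound 4 (`O=C(NCc1ccc(S(=O)(=O)c2cccc(C(F)(F)F)c2)cc1)c1ccc2nccn2c1`) keeps the sulfonyl side of compound 2 and carries this change: a group of 9 heavy atoms (7 carbon, 2 nitrogen; one five-membered aromatic ring with 2 hetero atoms, one six-membered aromatic ring with 1 hetero atom) in place of a group of 9 heavy atoms (7 carbon, 1 nitrogen, 1 oxygen; one five-membered aromatic ring with 1 hetero atom, one six-membered aromatic ring with 1 hetero atom), on a carbonyl carbon. Among the compounds with values here, the one measured step, a number 8 percentage points higher from compound 2 to compound 3 (within the scatter), lies on the sulfonyl sulfur and not at this carbonyl carbon, so it offers no direct size. The entering group occurs in compound 1, which also lacks the trifluoromethyl of compound 2, so compound 1 at 77% is only a partial guide. An upward step is expected, estimated as a number 18 percentage points higher from compound 2 to compound 4 (beyond the scatter). Compound 4 is expected at 66%, with an estimated range of 50% to 82%.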

Compound 4, percent of the compound remaining: 26%
Compound 4: middle estimate off by 40 percentage points, on the high side, outside the stated range (below it).
By their numbers in this assay, from the lowest: compound 4; then compounds 2 and 3 (each within the scatter of the next); then compound 1.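

In this assay the change on the carbonyl carbon gives a number 22 percentage points lower from compound 2 to compound 4 (beyond the scatter) and so runs downward, which shows that the group found in compound 1 does not by itself hold the number up. Trifluoromethyl in place of hydrogen on an aromatic carbon gives a number 51 percentage points lower from compound 1 to compound 4 (beyond the scatter) as the larger of the two steps, so the high value of compound 1 does not survive this one substitution. Nothing shown gives a reason for either step.

From the compounds shown here alone, how a chloro or methoxy group in place of trifluoromethyl would fare on the core of compound 1 stays open. So does whether the carbonyl change would run the same way with piperidin-1-yl on the sulfonyl sulfur, as in compound 3.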